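Shifting Two Methyl Groups on a Ring-Nitrogen Phenyl

The source may report more compounds than this note shows. Statements on the series, on what has been measured and on what is new or still open speak of the compounds shown alone.

Measured so far, in one cell assay:
compound 1 `Oc1cc(C(F)(F)F)ccc1-c1nc(-c2ccccc2O)n(-c2ccc(F)cc2)n1`: 99.8%
compound 2 `Oc1cc(C(F)(F)F)ccc1-c1nc(-c2ccccc2O)n(-c2ccccc2Cl)n1`: 102%
compound 3 `Cc1ccc(-n2nc(-c3ccc(C(F)(F)F)cc3O)nc2-c2ccccc2O)c(C)c1`: 106%

The three compounds share one core and differ only in the group carried on an aromatic nitrogen. In a functional assay on PC-12 cells (Rattus norvegicus) for cytotoxicity, read by MTT assay, with stated times of 2 h and 24 h, tested at 10 uM (on this read-out higher numbers stand for a stronger effect at the one concentration tested and lower numbers for a weaker effect), the numbers sit close together. Compound 3 holds the largest of the three, yet both steps leading to it, a number 6.2 percentage points higher from compound 1 to compound 3 (within the scatter) and a number 4 percentage points higher from compound 2 to compound 3 (within the scatter), lie within the scatter, as does a number 2.2 percentage points higher from compound 1 to compound 2 (within the scatter). On these numbers, then, compound 3 is not separated from compound 1 or compound 2.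

Compound 4 `Cc1cc(C)cc(-n2nc(-c3ccc(C(F)(F)F)cc3O)nc2-c2ccccc2O)c1` is the next step: 3,5-dimethylphenyl in place of 2,4-dimethylphenyl on an aromatic nitrogen. The three measured steps all swap the group on this same aromatic nitrogen, and none of them shifted the result in this assay beyond the scatter, so the step from compound 3 is expected to be small, a number 2 percentage points lower from compound 3 to compound 4 (within the scatter). Compound 4 is therefore expected to give 104% in this assay, within a range from 94% to 114%.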

Compound 4, a percentage reported as activity, at one concentration (the size of the read-out at that concentration, not a potency): 105%
The estimate for compound 4 lay 1 percentage points below the measured number; the range from low to high includes it.
By their numbers in this assay, from the lowest: compounds 1, 2, 4 and 3 (each within the scatter of the next).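

Compound 4 carries the same atoms as compound 3, with only the two methyl groups placed differently on the phenyl ring, and this rearrangement gives a number 1 percentage points lower from compound 3 to compound 4 (within the scatter) in this assay. Going by these compounds alone, the earlier compounds all differed in which atoms the group contained, so this is the first sign that moving the methyl groups around that ring does not separate two compounds here. The 3,5-dimethylphenyl group is also not separated from the other two groups, with a number 3 percentage points higher from compound 2 to compound 4 (within the scatter) and a number 5.2 percentage points higher from compound 1 to compound 4 (within the scatter), so all four compounds remain together on this read-out.

From the compounds shown here alone, whether a group carrying an amine or a carboxylic acid, or a longer alkyl chain, on this aromatic nitrogen would move the number beyond the scatter remains open. Nothing available explains why these four groups give such close numbers.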